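The source may hold more compounds than are shown below. What is called first, only, known or untested is meant among the compounds shown, and "the series" means these compounds.

Measured so far:
Compound 1 `C=CCCCCOc1cc2ccccc2cc1-c1cnc(OCCCCC=C)n1C` - "not determined" (no result reported)
Compound 2 `C=CCCCCOc1ncc(-c2cc(C(C)C)ccc2OC)n1C` - 7000 nM

For the measured compounds named here, compound 1 has no reported result in a functional assay on B16-F10 cells (Mus musculus) for inhibition, read by colorimetric assay and MTT assay, with a stated time of 72 h (on this read-out higher numbers stand for weaker inhibition and lower numbers for stronger inhibition), so compound 2 at 7000 nM is the only number on the scale and has no measured neighbour to be ranked against. Compound 3 `C=CCCCCOc1ncc(-c2cc(C(F)(F)F)ccc2OC)n1C` differs from compound 2 by trifluoromethyl in place of isopropyl on an aromatic carbon, with trifluoromethyl in place of isopropyl on an aromatic carbon. Going by the values given here, no measured pair shows what this change does in this assay, so no step beyond the scatter is expected in either direction. The expected 1.1-fold higher number from compound 2 to compound 3 (0.06 log units; within the scatter) is therefore small. Compound 3 is estimated at 8000 nM with an expected range from 2500 nM to 25000 nM.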

Compound 3, half-maximal inhibitory concentration: 59000 nM
For compound 3 the middle estimate is 7.4-fold (0.87 log units) below the measured one; the measured number lies above the stated range.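

In this assay, the aromatic carbon meta to a large group and para to a methoxy group proves sensitive to what it carries: trifluoromethyl in place of isopropyl gives an 8.4-fold higher number from compound 2 to compound 3 (0.93 log units; beyond the scatter), so the stronger inhibition stays with isopropyl. For the compounds shown here, this is the first measured step here, and it arises from an exchange that adds just one heavy atom. Nothing at hand accounts for the step. Going by these compounds, what an amine, a carboxylic acid or a longer chain would do at this position remains open, as does whether the same exchange has a similar effect with other groups on the shared core.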